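Trading a sulfonamide arm for a plain nonyl chain

This account rests on a few compounds, and the source may have more. Where it says the series, first, only, none or still open, it means among the compounds named here.

Measured compounds:
- compound 1 `COc1ccc(-c2cn(C/C=C3\OC(=O)C(OCc4ccccc4)=C3OCc3ccccc3)nn2)cc1`: > 100000 nM
- compound 2 `O=C1O[C@H]([C@@H](O)Cn2cc(CNS(=O)(=O)c3ccc(F)cc3)nn2)C(OCc2ccccc2)=C1OCc1ccccc1`: 22900 nM
- compound 3 `CCCCCc1ccc(-c2cn(C/C=C3\OC(=O)C(OCc4ccccc4)=C3OCc3ccccc3)nn2)cc1`: > 100000 nM

Among the measured compounds shown here, in a functional assay on HCT-116 cells (Homo sapiens) for antiproliferative activity, read by MTT assay, with a stated time of 72 h (on this read-out higher numbers stand for weaker inhibition and lower numbers for stronger inhibition), compound 2 gives 22900 nM, the only number among the three results. Compound 1 reaches only a limit of the assay, > 100000 nM. Compound 3 likewise stops at a limit, > 100000 nM. For the measured compounds named here, the one measured step, a step that the two limits leave unreadable from compound 1 to compound 3, is therefore unreadable, and it concerns a change on an aromatic carbon, not the change now at hand.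

Compound 4 `CCCCCCCCCCc1cn(C[C@H](O)[C@H]2OC(=O)C(OCc3ccccc3)=C2OCc2ccccc2)nn1` is not yet measured. Its difference from compound 2 is nonyl in place of ((4-fluorophenyl)sulfonyl)amino on a saturated chain carbon bound to an aromatic carbon. Going by the values given here, no measured step covers this kind of exchange, so no size or direction can be read from the data; the shared core is kept, and compound 2 remains the sole anchor with a number. Since the limit of > 100000 nM in this assay, at which 2 of the 3 values shown sit, is where two of three compounds sit, a limit is a real possibility for compound 4 as well.

With nothing pointing either way, compound 4 is expected to stay near compound 2, at an estimated 25000 nM (range 6000 nM to 100000 nM). The step this estimate implies, a 1.1-fold higher number from compound 2 to compound 4 (0.04 log units; within the scatter), is expected to lie within the scatter.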

Compound 4, half-maximal inhibitory concentration: 28800 nM
For compound 4 the middle estimate is 1.2-fold (0.06 log units) below the measured one; the range from low to high includes it.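

Measured in this assay, putting nonyl in place of ((4-fluorophenyl)sulfonyl)amino on a saturated chain carbon bound to an aromatic carbon gives a 1.3-fold higher number from compound 2 to compound 4 (0.10 log units; within the scatter), so this read-out does not tell the two compounds apart. At this place, then, the aromatic ring, the fluorine, the sulfur and the hydrogen-bond donor and acceptors of the leaving group can all give way to a plain chain, at least in this one pair, and the number stays within the usual scatter. Compound 1 and compound 3 remain the two that stop at a limit of the assay, which is not a number: the limit of > 100000 nM in this assay, at which 2 of the 4 values shown sit.

Open, on these data alone, is how a shorter chain such as butyl, a longer chain such as tetradecyl, an amine or a carboxylic acid would read at this same place, since one exchange says nothing about the groups on either side of it. Also open, as far as these compounds go, is whether this exchange would read the same on the core of compound 1, and the step between the two limits cannot be read.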